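The source may hold more compounds than are shown below. What is called first, only, known or untested is meant among the compounds shown, and "the series" means these compounds.

Of the compounds shown here, two have already been tested in a functional assay, tested at 50 ug/mL; a higher number here means a stronger effect of the compound at the concentration tested, a lower number a weaker effect. Compound 1, with the structure `N#CC1=C(N)OC(c2c[nH]c3ccccc23)=C(C#N)C1c1ccccc1F`, is reported in this assay as "not active" (no number reported), without a number attached. Compound 2, with the structure `Cc1ccc(C2C(C#N)=C(N)OC(c3c[nH]c4ccccc34)=C2C#N)cc1`, gives in this assay 5.2%. That makes compound 2 the holder of the only number shown so far, with the entry for compound 1 standing beside it without a single figure, so there is no measured step between two compounds from which the size of a structural effect could be read.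

The step now followed leads from compound 2 to compound 3, whose structure is `COc1ccc(C2C(C#N)=C(N)OC(c3c[nH]c4ccccc34)=C2C#N)cc1`. The change is methoxy in place of methyl on an aromatic carbon, a methoxy in place of a methyl on an aromatic carbon of a six-membered aromatic ring of carbon only.

Nothing in the numbers at hand points to a shift beyond the usual scatter, so the step from compound 2 to compound 3 is expected to amount to a number 0.2 percentage points lower from compound 2 to compound 3 (within the scatter). Compound 3 is therefore estimated at 5% in this assay, within a range from 0% to 15%.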

Compound 3, a percentage reported as activity, at one concentration (the size of the read-out at that concentration, not a potency): 12.4%
Compound 3: middle estimate off by 7.4 percentage points, on the low side; measured number inside the range.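

Within the data shown here, this is the first step that can be read as a number: in this assay, methoxy in place of methyl on an aromatic carbon, para to a large group, gives a number 7.2 percentage points higher from compound 2 to compound 3 (within the scatter). At this position, therefore, going from 4-methylphenyl to 4-methoxyphenyl, a change that brings in one more heavy atom, an oxygen, and one hydrogen-bond acceptor, does not separate the two compounds in this read-out by more than repeated measurements would. No measurement shown bears on the size of this step, so the data give no account of it.

The compounds shown leave open whether any group at this position would move the read-out beyond the scatter, for instance an amine, a carboxylic acid or a longer chain such as butoxy, since only methyl and methoxy can be compared here. Among these compounds, they also leave open how the ring substituent of compound 1 , a fluorine on the phenyl ring, relates to these two, as its entry carries no number and no step to it can be read.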